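Cytotoxicity on HOS cells: a ring change at the core

The source may report more compounds than this note shows. Statements on the series, on what has been measured and on what is new or still open speak of the compounds shown alone.

Compound 1, `CC(C)CN(Cc1cn2c(N3CCN(C)CC3)cccc2n1)[C@H]1CCCc2cccnc21`: 20000 nM
Compound 2, `CN(Cc1cn2c(N3CCC(N)CC3)cccc2n1)[C@H]1CCCc2cccnc21`: 6300 nM
Compound 3, `CCCN(Cc1cn2c(N3CCN(C)CC3)cccc2n1)[C@H]1CCCc2cccnc21`: 6700 nM

In an ADME assay on HOS cells (Homo sapiens) for cytotoxicity (on this read-out higher numbers stand for lower toxicity in this test and lower numbers for higher toxicity in this test), compound 2 gives 6300 nM. Compound 2 sits within the scatter of compound 3, while compound 1 lies beyond the scatter above it. Within the data shown here, the only measured step, a 3.0-fold lower number from compound 1 to compound 3 (0.47 log units; beyond the scatter), concerns the chain on the amine nitrogen, not the ring on the core.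

Compound 4, `CN(Cc1cn2c(N3CCN4CCCC4C3)cccc2n1)[C@H]1CCCc2cccnc21`, differs from compound 2 at the core: a group of 9 heavy atoms (7 carbon, 2 nitrogen; one five-membered non-aromatic ring with 1 hetero atom, one six-membered non-aromatic ring with 2 hetero atoms) in place of a group of 7 heavy atoms (5 carbon, 2 nitrogen; one six-membered non-aromatic ring with 1 hetero atom), on an aromatic carbon. No measured step bears on this change, so the data give no direction for it; the one step shown, on another part of the molecule, was modest, and ring changes at this position are untested here.

Compound 4 is therefore expected to give a number in this assay close to that of compound 2, with a step of about a 1.1-fold higher number from compound 2 to compound 4 (0.05 log units; within the scatter) that is not expected to exceed the scatter. The estimate for compound 4 is 7000 nM, with a range from 2500 nM to 20000 nM.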

Compound 4, half-maximal cytotoxic concentration: 3900 nM
Beside the measured number, compound 4's estimate is 1.8-fold (0.25 log units) above it, within the range that was stated.
By their numbers in this assay, from the lowest: compounds 4, 2 and 3 (each within the scatter of the next); then compound 1.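

The ring at this position now has a measured step in this assay: with the 4-aminopiperidin-1-yl group replaced by a group of one five-membered and one six-membered non-aromatic ring, the change is a 1.6-fold lower number from compound 2 to compound 4 (0.21 log units; within the scatter). On this pair, then, a larger group with 0 hydrogen-bond donors in place of one with 1 hydrogen-bond donor, on this aromatic carbon, does not move the read-out beyond the scatter, so this position tolerates the exchange in this test. Nothing measured here accounts for the size of this step.

From the compounds shown here alone, whether a morpholine ring, an open-chain amine or a carboxylic acid on this aromatic carbon would move this assay beyond the scatter remains open. Also open, going by these compounds, is whether this exchange would behave the same way with the longer chains on the amine nitrogen seen in compound 1 and compound 3.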